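Aryl amide sulfonamides: exchanging the benzoyl substituents

A few compounds are considered here, and "the series" means these few. Any claim that something is new, unique, unknown or untested is made for them only; others in the source may bear on it.

Compound 1 `O=C(Nc1ccc(S(=O)(=O)Nc2ccc(Cl)cc2)cc1)c1ccc(Cl)cc1Cl`: in a functional assay on HEK293 cells for agonist activity at probable G-protein coupled receptor 27 (Homo sapiens), read by a luciferase reporter and beta-arrestin recruitment, with a stated time of 10 min (on this read-out lower numbers stand for an effect already at smaller amounts and higher numbers for an effect only at larger amounts of compound), compound 1 is reported only as a limit, > 100000 nM.
Compound 2 `N#Cc1ccc(C(=O)Nc2ccc(S(=O)(=O)Nc3ccccc3)cc2)c(F)c1`: in this assay compound 2 gives 229 nM.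
Compound 3 `O=C(Nc1ccc(S(=O)(=O)Nc2ccccc2)cc1)c1ccc(Cl)cc1Br`: in this assay compound 3 gives 1020 nM.

Compound 3 stands highest of the two numbers obtained so far; its nearest neighbour is compound 2, a 4.5-fold higher number from compound 2 to compound 3 (0.65 log units; beyond the scatter). Compound 1 is a limit only (the limit of > 100000 nM in this assay, at which 1 of the 3 values shown sits). Among the measured compounds shown here, compound 1 differs from compound 3 in two places at once, so it yields no single step.

Compound 4 `Cc1cc(Br)ccc1C(=O)Nc1ccc(S(=O)(=O)Nc2ccccc2)cc1` is not yet measured. It differs from compound 3 by 4-bromo-2-methylphenyl in place of 2-bromo-4-chlorophenyl on a carbonyl carbon. For the measured compounds named here, only one measured step touches this carbonyl carbon: a 4.5-fold higher number from compound 2 to compound 3 (0.65 log units; beyond the scatter). Going by the values given here, that step exchanged a nitrile-bearing aryl for a halogenated one; the present change keeps a halogenated aryl and shifts the bromine and replaces the chlorine with a methyl, a kind of exchange for which no measured step exists. Without a precedent pointing either way, the number for compound 4 is expected near that of compound 3, with wide uncertainty.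

Compound 4 is therefore estimated at 1500 nM in this assay, with a range from 300 nM to 8000 nM. This estimate amounts to an expected 1.5-fold higher number from compound 3 to compound 4 (0.17 log units; within the scatter).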

Compound 4, half-maximal effective concentration: 851 nM
Compound 4: middle estimate off by 1.8-fold (0.25 log units), on the high side; measured number inside the range.
By their numbers in this assay, from the lowest: compound 2; then compounds 4 and 3 (each within the scatter of the next). At a limit, above all of these: compound 1.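

At this carbonyl carbon, 4-bromo-2-methylphenyl in place of 2-bromo-4-chlorophenyl gives a 1.2-fold lower number from compound 3 to compound 4 (0.08 log units; within the scatter) in this assay, so this exchange of one halogen-bearing aryl group for another, the first of its kind in the series, does not separate the two groups. The step of a 3.7-fold higher number from compound 2 to compound 4 (0.57 log units; beyond the scatter) stands with the earlier step of a 4.5-fold higher number from compound 2 to compound 3 (0.65 log units; beyond the scatter) and both lie beyond the scatter, so two differently substituted aryl groups without a nitrile now give higher numbers than 4-cyano-2-fluorophenyl, and compound 2 has the lowest number of the three. Nothing measured in the compounds shown gives a reason for these numbers.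

Because the nitrile and the fluorine leave together in both steps from compound 2, the compounds shown do not tell which of the two goes with the lower number, and an aryl group carrying only one of them would be needed to separate them. As far as these compounds go, how an amine or a carboxylic acid on this aryl group would read in this assay also remains open.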